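This account rests on a few compounds, and the source may have more. Where it says the series, first, only, none or still open, it means among the compounds named here.

Compound 1 `COc1cc(C)cc(-c2c(-c3ccnc(-c4ccc(C(C)=O)cc4)c3)cnn2CC#N)c1`: 2630 nM
Compound 2 `COc1cc(C)cc(-c2nn(CC#N)cc2-c2ccnc(-c3ccc(N(C)C)cc3)c2)c1`: 626 nM

In a functional assay on MOLT-4 cells (Homo sapiens) for inhibition, read by sulforhodamine B assay, with a stated time of 48 h (on this read-out lower numbers stand for stronger inhibition of growth and higher numbers for weaker inhibition of growth), compound 1 gives 2630 nM, the highest of the two numbers. Compound 2 gives 626 nM in this assay, a lower number beyond the scatter. Compound 3 `COc1cc(C)cc(-c2c(-c3ccnc(-c4ccc(N(C)C)cc4)c3)cnn2CC#N)c1` is not yet measured. It differs from compound 1 in one place: dimethylamino in place of acetyl on an aromatic carbon. Going by the values given here, no measured pair shows this exact step, so the expected step from compound 1 to compound 3 , a 3.3-fold lower number from compound 1 to compound 3 (0.52 log units; beyond the scatter), is a guess toward a lower number, partly because compound 2 carries the dimethylamino group and gives 626 nM. Compound 3 is therefore expected at about 800 nM, within 250 nM to 2500 nM.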

Compound 3, concentration for 50% growth inhibition: 271 nM
Beside the measured number, compound 3's estimate is 3.0-fold (0.47 log units) above it; measured number inside the range.
By their numbers in this assay, from the lowest: compound 3; then compound 2; then compound 1.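

In this assay, changing 4-acetylphenyl to 4-(dimethylamino)phenyl gives a 9.7-fold lower number from compound 1 to compound 3 (0.99 log units; beyond the scatter). Going by these compounds alone, this is the first comparison in which only this group changes while the rest of the molecule stays the same, so it shows that growth inhibition depends strongly on the group at this place, para to a large group. No measurement here explains why the number falls. The compounds shown leave open how a primary amine or a carboxylic acid would compare at this place, and whether longer chains on the nitrogen would keep the lower number.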